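A few compounds are considered here, and "the series" means these few. Any claim that something is new, unique, unknown or untested is made for them only; others in the source may bear on it.

Measured compounds in an assay on CHO cells for displacement of a labelled ligand from adenosine receptor A2b (Homo sapiens), read by scintillation counting, with a stated time of 75 min, in the presence of a further agent that is not named here; a lower number here means a stronger inhibitor, a higher number a weaker inhibitor:
- compound 1, `CCCn1c(=O)[nH]c2nc(-c3ccc(S(=O)(=O)N4CCN(c5ccc(Br)cc5)CC4)cc3)[nH]c2c1=O`: 0.0835 nM
- compound 2, `CCCn1c(=O)[nH]c2nc(-c3ccc(S(=O)(=O)N4CCN(Cc5cccc(Br)c5)CC4)cc3)[nH]c2c1=O`: 0.148 nM
- compound 3, `CCCn1c(=O)[nH]c2nc(-c3ccc(S(=O)(=O)N4CCN(c5ccccc5Br)CC4)cc3)[nH]c2c1=O`: 0.137 nM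

All three share one core and differ only in the group carried on the amine nitrogen in the six-membered non-aromatic ring with two nitrogens. Compound 3 gives the second highest of the three numbers in this assay, but every step among them is within the scatter: a 1.6-fold higher number from compound 1 to compound 3 (0.22 log units; within the scatter), a 1.8-fold higher number from compound 1 to compound 2 (0.25 log units; within the scatter) and a 1.1-fold lower number from compound 2 to compound 3 (0.03 log units; within the scatter). Moving the bromine round the phenyl ring, or inserting a benzyl linker, has therefore left no step beyond the scatter in this series.

Compound 4, `CCCn1c(=O)[nH]c2nc(-c3ccc(S(=O)(=O)N4CCN(c5cccc(F)c5)CC4)cc3)[nH]c2c1=O`, is not yet measured. It differs from compound 3 in one place: 3-fluorophenyl in place of 2-bromophenyl on an amine nitrogen in a ring. The closest measured step is the exchange of one bromophenyl for another, shown by a 1.6-fold higher number from compound 1 to compound 3 (0.22 log units; within the scatter), which was within the scatter. Among the measured compounds shown here, no measured pair tells anything about a fluorine in place of a bromine on this ring, so the step from compound 3 to compound 4 is expected to be small, with no clear direction beyond the scatter: a 1.1-fold higher number from compound 3 to compound 4 (0.04 log units; within the scatter). Compound 4 is therefore estimated at 0.15 nM in this assay, within a range of 0.06 nM to 0.4 nM, to be confirmed once the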

Compound 4, inhibition constant: 0.632 nM
Estimate against measurement, compound 4: 4.2-fold (0.62 log units) below; the measured number lies above the stated range.
By their numbers in this assay, from the lowest: compounds 1, 3 and 2 (each within the scatter of the next); then compound 4.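

Among the compounds shown here, at this position, on an amine nitrogen in the ring, the series now holds its only steps beyond the scatter in this assay: a 4.6-fold higher number from compound 3 to compound 4 (0.66 log units; beyond the scatter) and a 4.3-fold higher number from compound 2 to compound 4 (0.63 log units; beyond the scatter) and a 7.6-fold higher number from compound 1 to compound 4 (0.88 log units; beyond the scatter). For the compounds shown here, the group on this nitrogen therefore does matter to the number, since the three bromine-bearing groups remain within the scatter of one another while the one fluorine-bearing group, in compound 4, stands apart from all of them, even though 2-bromophenyl and 3-fluorophenyl have the same heavy-atom count, with no hydrogen-bond donors or acceptors and no net charge. Nothing on hand accounts for this gap.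

The step from compound 3 to compound 4 changes both the halogen and its place on the phenyl ring, so the compounds shown cannot separate the two changes, and a single fluorine-bearing compound supports no general rule about fluorine against bromine. Open comparisons at this nitrogen include 3-bromophenyl, 2-fluorophenyl, 4-fluorophenyl and unsubstituted phenyl, and also a phenyl ring carrying an amine or a carboxylic acid.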